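This account rests on a few compounds, and the source may have more. Where it says the series, first, only, none or still open, it means among the compounds named here.

Values from a functional assay on PC-3 cells (Homo sapiens) for cytotoxicity, read by MTT assay, with a stated time of 72 h (on this read-out lower numbers stand for stronger inhibition and higher numbers for weaker inhibition), so far:
- compound 1 `O=C(N/N=C/c1ccc(F)cc1Cl)Nc1cc2c(Nc3ccc(F)c(Cl)c3)ncnc2cc1O[C@H]1CCOC1` gives 28400 nM
- compound 2 `O=C(N/N=C/c1cc(Br)c(O)c(Br)c1)Nc1cc2c(Nc3ccc(F)c(Cl)c3)ncnc2cc1O[C@H]1CCOC1` gives 6160 nM

Compound 1 holds the higher of these two numbers, so it is the weaker of the pair. Compound 3 `COc1cc2ncnc(Nc3ccc(F)c(Cl)c3)c2cc1NC(=O)N/N=C/c1ccc(F)cc1Cl` has not yet been measured. It carries methyl in place of oxolan-3-yl on an oxygen on an aromatic ring. For the measured compounds named here, the only measured step (a 4.6-fold lower number from compound 1 to compound 2 (0.66 log units; beyond the scatter)) was modest, but it lies on a carbon with a double bond to nitrogen, so no measured step bears directly on this change. The expected step (a 1.1-fold lower number from compound 1 to compound 3 (0.06 log units; within the scatter)) is therefore none beyond the scatter in this assay, with wide uncertainty. Compound 3 is estimated at 25000 nM (expected range 9000 nM to 70000 nM).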

Compound 3, half-maximal inhibitory concentration: 25700 nM
Compound 3: middle estimate off by 1.0-fold (0.01 log units), on the low side; the range from low to high includes it.
By their numbers in this assay, from the lowest: compound 2; then compounds 3 and 1 (each within the scatter of the next).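

In this assay, for the compounds shown here, methyl in place of oxolan-3-yl on the oxygen on an aromatic ring gives the first measured step at this position (a 1.1-fold lower number from compound 1 to compound 3 (0.04 log units; within the scatter)). With the 2-chloro-4-fluorophenyl group in place, compound 1 and compound 3 cannot be told apart, so the five-membered ring and its defined stereocentre can be removed without a change beyond the scatter. No measurement here offers an explanation for this result.

From the compounds shown here alone, whether this also holds with the 3,5-dibromo-4-hydroxyphenyl group of compound 2 stays open. So does the effect of a longer chain ending in an amine on this oxygen.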